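The compounds below may be only part of what the source reports. "The series", "measured", "known", "first", "only" and "open" are said of these compounds alone.

Notes on the series. In a functional assay on MCF7 cells (Homo sapiens) for inhibition, read by sulforhodamine B assay (on this read-out lower numbers stand for stronger inhibition and higher numbers for weaker inhibition), compound 1 `O=C1C(Nc2ccc(C(F)(F)F)cc2)=CC(=O)c2c1nc1n2[C@H]2OC[C@@H](O)[C@H]2OC1` gives > 4000 nM, which is a limit of the assay and not a number. Compound 1 therefore stands at the limit of > 4000 nM in this assay, at which 1 of the 2 values shown sits, so its true inhibition is only bounded on one side. Compound 2 `CCOc1ccc(NC2=CC(=O)c3nc4n(c3C2=O)[C@H]2OC[C@@H](O)[C@H]2OC4)cc1` gives in this assay a measured number, 1430 nM. Compound 3 `O=C1C(Nc2cccc(F)c2)=CC(=O)c2c1nc1n2[C@H]2OC[C@@H](O)[C@H]2OC1` is not yet measured; it differs from compound 1 by 3-fluorophenyl in place of 4-(trifluoromethyl)phenyl on an amine nitrogen. Among the compounds with values here, no measured step between the compounds covers this change, so its direction remains open; a modest step toward stronger inhibition is expected, an at least 1.3-fold lower number from compound 1 to compound 3 (0.12 log units; that floor lies within the scatter), though a limit again is possible. For compound 3 the estimate in this assay is 3000 nM, with a range from 800 nM to 10000 nM.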

Compound 3, half-maximal inhibitory concentration: > 4000 nM
Compound 3 was reported as a limit; the forecaster's own chance of this, stated with the estimate: 40%; at least 1.3-fold (0.12 log units) between middle value and limit.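

Within the data shown here, compound 1 and compound 3 both stand at a limit of this assay, so no step between them can be read. Going by these compounds, it remains open whether 3-fluorophenyl or 4-(trifluoromethyl)phenyl on an amine nitrogen gives stronger inhibition.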